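Chloro in Place of Bromo: What to Expect

This account rests on a few compounds, and the source may have more. Where it says the series, first, only, none or still open, it means among the compounds named here.

In a functional assay on NALM-6 cells (Homo sapiens) for cytotoxicity, read by luminescence and CellTiter-Glo, with a stated time of 3 days (a lower number here means a stronger inhibitor, a higher number a weaker inhibitor), compound 1 `O=C(Nc1cc(C(F)(F)F)cc(C(F)(F)F)c1)c1cc(Br)c(-c2ccccc2)cc1O` gives 840 nM. Compound 2 `O=C(Nc1cc(C(F)(F)F)cc(C(F)(F)F)c1)c1cc(Br)ccc1O` gives 590 nM. Within the data shown here, these are the only two numbers so far, and they lie within the scatter of each other, so compound 1 has no clear rank. Compound 3 `O=C(Nc1cc(C(F)(F)F)cc(C(F)(F)F)c1)c1cc(Cl)c(-c2ccccc2)cc1O` differs from compound 1 in one place: chloro in place of bromo on an aromatic carbon. This puts chloro in place of bromo on an aromatic carbon. Among the measured compounds shown here, no measured step makes this swap. For the measured compounds named here, the one measured step, a 1.4-fold lower number from compound 1 to compound 2 (0.15 log units; within the scatter), is a different change, hydrogen in place of phenyl on an aromatic carbon, and it stayed within the scatter. It offers only indirect guidance, so no shift beyond the scatter is expected in this assay, and no direction can be favoured. The expected step is a 1.1-fold lower number from compound 1 to compound 3 (0.02 log units; within the scatter). For compound 3 the estimate is 800 nM, with an expected range of 400 nM to 1600 nM.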

Compound 3, half-maximal inhibitory concentration: 560 nM
The estimate for compound 3 lay 1.4-fold (0.15 log units) above the measured number; the measured number falls inside the stated range.
By their numbers in this assay, from the lowest: compounds 3, 2 and 1 (each within the scatter of the next).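

Chloro in place of bromo, on the carbon para to a hydroxy group and ortho to a phenyl group, gives the first direct look at the halogen at this position. In this assay the change gives (a 1.5-fold lower number from compound 1 to compound 3 (0.18 log units; within the scatter)), so the two halogens cannot be told apart here, at least with the phenyl group in place. Nothing measured on these compounds explains this result.

The compounds shown leave open whether a quite different group at this position, such as an amine, a methoxy group or a carboxylic acid, would move the number beyond the scatter. They also leave open whether chloro and bromo would still match on the core of compound 2, which has hydrogen in place of the phenyl group.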